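Swapping 4-carboxyphenyl for 3,4-dimethoxyphenyl at the assay limit

A few compounds are considered here, and "the series" means these few. Any claim that something is new, unique, unknown or untested is made for them only; others in the source may bear on it.

In a functional assay on MDA-MB-435 cells (Homo sapiens) for inhibition, read by MTT assay, with a stated time of 72 h (on this read-out lower numbers stand for stronger inhibition and higher numbers for weaker inhibition), compound 1 `COc1ccc(-c2ccc(-c3ccc(C(=O)O)cc3)c(OC)c2OC)cc1OC` gives > 100000 nM as a limit of the assay and not a number. Compound 2 `CCOc1c(-c2ccc(OC)c(OC)c2)ccc(-c2ccc(OC)c(OC)c2)c1OCC` shows > 100000 nM in the same test, again only a limit. The picture so far is the limit of > 100000 nM in this assay, at which 2 of the 2 values shown sit, with no number to set a step against. Compound 3 `COc1ccc(-c2ccc(-c3ccc(OC)c(OC)c3)c(OC)c2OC)cc1OC` carries 3,4-dimethoxyphenyl in place of 4-carboxyphenyl on an aromatic carbon. For the measured compounds named here, no measured step guides this change, and only a small move toward stronger inhibition is expected (an at least 1.4-fold lower number from compound 1 to compound 3 (0.15 log units; that floor lies within the scatter)). In this assay compound 3 is estimated at 70000 nM within an expected range of 8000 nM to 300000 nM and may well report only a limit.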

Compound 3, half-maximal inhibitory concentration: 90800 nM
Estimate against measurement, compound 3: 1.3-fold (0.11 log units) below; measured number inside the range.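

In this assay, for the compounds shown here, compound 3 gives the first value that is a number and not a limit, so 3,4-dimethoxyphenyl on this aromatic carbon brings the series into measurable range. The step can be read only as a floor: an at least 1.1-fold lower number from compound 1 to compound 3 (0.04 log units; that floor lies within the scatter). It therefore does not establish stronger inhibition, and most values remain at the limit: the limit of > 100000 nM in this assay, at which 2 of the 3 values shown sit. On these data alone, how far compound 3 truly lies from compound 1 stays open. So does whether an amine or a longer alkoxy chain at this place would lower the number further.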